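Ethyl to methyl on the piperidine of compound 1

The source may hold more compounds than are shown below. What is called first, only, known or untested is meant among the compounds shown, and "the series" means these compounds.

Compound 1 `CCC1CCCN(C(=O)CN2CN(c3ccccc3)C3(CCN(C(=O)c4ccc(C(C)(C)C)cc4)CC3)C2=O)C1` is measured in an assay on HEK293 cells for displacement of a labelled ligand from NPC1-like intracellular cholesterol transporter 1 (Homo sapiens) (on this read-out lower numbers stand for stronger inhibition and higher numbers for weaker inhibition), at 3900 nM. Compound 2 `CS(=O)(=O)NCCCNC(=O)CN1CN(c2ccccc2)C2(CCN(C(=O)c3ccc(C4CCCCC4)cc3)CC2)C1=O` gives in this assay a value of 3800 nM; the two numbers lie within the scatter of each other, so compound 1 stands as one of two closely matched values and neither is set apart from the other. Compound 3 `CC1CCCN(C(=O)CN2CN(c3ccccc3)C3(CCN(C(=O)c4ccc(C(C)(C)C)cc4)CC3)C2=O)C1` has not yet been measured in this assay. It differs from compound 1 in one place: hydrogen in place of methyl on a saturated chain carbon bound to a saturated ring carbon. Within the data shown here, no step between measured compounds covers this change, and the two numbers at hand give no indication of how the read-out answers to it. The expectation for compound 3 is therefore a step of a 1.2-fold higher number from compound 1 to compound 3 (0.06 log units; within the scatter) that stays within the scatter, with no particular direction. Compound 3 is expected to give 4500 nM in this assay, within a range of 1800 nM to 11000 nM.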

Compound 3, half-maximal inhibitory concentration: 12000 nM
The estimate for compound 3 lay 2.7-fold (0.43 log units) below the measured number; measured number outside the range, above it.
By their numbers in this assay, from the lowest: compounds 2 and 1 (each within the scatter of the next); then compound 3.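

Going from 3-ethylpiperidin-1-yl to 3-methylpiperidin-1-yl in this assay gives a 3.1-fold higher number from compound 1 to compound 3 (0.49 log units; beyond the scatter) and so provides the first reading of this place in the series. Hydrogen in place of methyl on a saturated chain carbon bound to a saturated ring carbon is therefore not a silent change here: the loss of one carbon moves the read-out beyond the scatter, with the ethyl group on the side of the lower number. No measurement on hand bears on why the read-out responds in this way.

From the compounds shown here alone, whether a longer chain such as propyl at this place would lower the number further remains open. Going by these compounds, whether the unsubstituted piperidin-1-yl would continue the trend also remains open. Also open, on these data alone, is how a hydroxyl or an amine on the ethyl group would read.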